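Series notes: allylsulfanyl in place of benzimidazolylmethylsulfanyl

The source may report more compounds than this note shows. Statements on the series, on what has been measured and on what is new or still open speak of the compounds shown alone.

Three compounds on the shared core have numbers in an ADME assay on GES1 cells (Homo sapiens) for inhibition, read by MTT assay, with a stated time of 72 h; a lower number here means a stronger inhibitor, a higher number a weaker inhibitor. Compound 1 `Cc1cc(Nc2cc(-c3ccc(Cl)cc3)[nH]n2)n2nc(SCc3ccc(Br)cc3)nc2n1` gives 28200 nM. Compound 2 `Cc1cc(Nc2cc(-c3ccccc3)[nH]n2)n2nc(SCc3nc4ccccc4[nH]3)nc2n1` gives 27800 nM, the lowest of the three, though its gap to compound 1 and to compound 3 is within the scatter. Compound 3 `Cc1cc(Nc2cc(-c3cccs3)[nH]n2)n2nc(SCc3ccc(Br)cc3)nc2n1` gives 38700 nM. Within the data shown here, the one single-point step, a 1.4-fold higher number from compound 1 to compound 3 (0.14 log units; within the scatter), sits on an aromatic carbon and is within the scatter.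

Compound 4 `C=CCSc1nc2nc(C)cc(Nc3cc(-c4ccccc4)[nH]n3)n2n1` is not yet measured. Its change from compound 2, (vinyl in place of 1H-benzimidazol-2-yl on a saturated chain carbon bound to a sulfur), is the replacement of the whole (1H-benzimidazol-2-yl)methyl by allyl on the sulfur. Among the measured compounds shown here, no measured step touches this position, so nothing here speaks for a shift in either direction; the three numbers so far all lie close together in this assay regardless of the group on the sulfur or on the aromatic carbon.

Compound 4 is therefore expected near the others, estimated at 30000 nM with a range of 14000 nM to 65000 nM; the expected step of a 1.1-fold higher number from compound 2 to compound 4 (0.03 log units; within the scatter) is none beyond the scatter.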

Compound 4, half-maximal inhibitory concentration: > 50000 nM
Compound 4 ended at the assay's limit (the forecaster's own chance of this, stated with the estimate: 20%); middle value at least 1.6-fold (0.22 log units) away from the limit.
By their numbers in this assay, from the lowest: compounds 2, 1 and 3 (each within the scatter of the next). At a limit, above all of these: compound 4.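

In this assay compound 4 gives > 50000 nM, which is a limit of the assay and not a number: the limit of > 50000 nM in this assay, at which 1 of the 4 values shown sits. Among these compounds, the first measured step at the group on the sulfur, an at least 1.7-fold higher number from compound 2 to compound 4 (0.25 log units; that floor lies within the scatter), has a floor within the scatter, so it shows no shift beyond the scatter, and how far the true number lies past the limit stays unknown. What it does show is that exchanging the (1H-benzimidazol-2-yl)methyl for allyl, which removes both aromatic rings and the hydrogen-bond donor of that group, does not bring the number down in this assay.

On these data alone, whether a saturated propyl chain, a longer chain or an amine on the sulfur would give a number short of the limit remains open. So does whether allyl reads the same with thiophen-2-yl or 4-chlorophenyl on the aromatic carbon.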